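Benzyl-purine series: fluoro on the benzyl ring

A few compounds are considered here, and "the series" means these few. Any claim that something is new, unique, unknown or untested is made for them only; others in the source may bear on it.

Compound 1 `c1ccc(CSc2ncnc3[nH]cnc23)cc1` — in an assay on isolated protein for inhibition of Ca2+/calmodulin-dependent protein kinase II (CaM kinase II) (Rattus norvegicus), tested at 30 uM (on this read-out lower numbers stand for less inhibition and higher numbers for more inhibition at the one concentration tested (going by the name of the read-out)), compound 1 gives 0%.
Compound 2 `Fc1ccc(C[n+]2c[nH]c3ncncc32)cc1` — in this assay compound 2 gives 5%.
Compound 3 `Clc1ncnc2c1ncn2Cc1ccccc1` — in this assay compound 3 gives 7%.

The three measured numbers sit close together. Compound 3 has the highest of the three, but the gap to compound 2, the nearest, and the gap to compound 1, the furthest, both lie within the usual scatter of this assay, so no ordering among compounds 1, 2 and 3 can be read from them; all three show little inhibition at the concentration tested.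

The next compound, compound 4 `Fc1ccc(Cn2cnc3c(Cl)ncnc32)cc1`, differs from compound 3 in one place: fluoro in place of hydrogen on an aromatic carbon. Among the measured compounds shown here, the benzyl ring of compound 2 carries the same fluoro group, and compound 2 in this assay gives 5%, in line with the unsubstituted benzyl of compound 3; no comparable pair with a shared core is measured.

The step from compound 3 to compound 4 in this assay is therefore expected to be small, estimated as a number 1 percentage points higher from compound 3 to compound 4 (within the scatter), not beyond the scatter in either direction. For compound 4 in this assay the expected value is 8%, in a range from 0% to 20%.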

Compound 4, a percentage reported as inhibition, at one concentration (the size of the read-out at that concentration, not a potency): 0%
Estimate against measurement, compound 4: 8 percentage points above; the range from low to high includes it.
By their numbers in this assay, from the lowest: compounds 1, 4, 2 and 3 (each within the scatter of the next).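

In this assay, the step of a number 7 percentage points lower from compound 3 to compound 4 (within the scatter) for fluoro in place of hydrogen on an aromatic carbon, para to a large group, gives the series its first comparison of two compounds that differ in one place. This small substitution on the benzyl ring therefore shows no effect that can be told from the scatter, and both compounds remain at little inhibition at the one concentration tested. No data on hand bear on why this is so.

From the compounds shown here alone, whether a larger group at this position, such as methoxy, trifluoromethyl or a carboxylic acid, would move the number beyond the scatter remains open. Also open, going by these compounds, is whether replacing the chloro group on the shared core with an amine or a longer chain would change the read-out.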